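Chloro for Methyl on a Weakly Active Sulfonamide

The source may hold more compounds than are shown below. What is called first, only, known or untested is meant among the compounds shown, and "the series" means these compounds.

Compound 1 `Cc1ccc(-n2cc(-c3ccccc3NS(=O)(=O)c3c[nH]c(=O)[nH]c3=O)nn2)cc1`: 8350 nM in a functional assay on HepG2 cells (Homo sapiens) for antiproliferative activity, read by MTT assay, with a stated time of 24 h; a lower number here means a stronger inhibitor, a higher number a weaker inhibitor.
Compound 2 `O=c1[nH]cc(S(=O)(=O)Nc2cccc(-c3cn(-c4ccccc4Cl)nn3)c2)c(=O)[nH]1`: 4030 nM.
Compound 3 `Cc1cccc(-n2cc(-c3ccc(NS(=O)(=O)c4c[nH]c(=O)[nH]c4=O)cc3)nn2)c1`: only a limit, > 20000 nM.

Compound 3 gives no number in this assay but only a limit, > 20000 nM, as stated by the limit of > 20000 nM in this assay, at which 1 of the 3 values shown sits. Going by the values given here, compounds 1 and 2 differ from it in more than one place, so their values show only that each registers a number where compound 3 does not.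

Compound 4 `O=c1[nH]cc(S(=O)(=O)Nc2ccc(-c3cn(-c4cccc(Cl)c4)nn3)cc2)c(=O)[nH]1` differs from compound 3 by chloro in place of methyl on an aromatic carbon, 3-methylphenyl becoming 3-chlorophenyl. Among the compounds with values here, no measured pair shows this change alone, so no step beyond the usual scatter is expected in this assay in either direction. Compound 4 is therefore expected near 15000 nM, within 5000 nM to 40000 nM, and may again be reported only as a limit. The step this estimate means, an at least 1.3-fold lower number from compound 3 to compound 4 (0.12 log units; that floor lies within the scatter), is expected to stay within the scatter.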

Compound 4, half-maximal inhibitory concentration: 2020 nM
Beside the measured number, compound 4's estimate is 7.4-fold (0.87 log units) above it; the measured number lies below the stated range.
By their numbers in this assay, from the lowest: compounds 4 and 2 (each within the scatter of the next); then compound 1. At a limit, above all of these: compound 3.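

In this assay, going by these compounds alone, chloro in place of methyl on this aromatic carbon gives the first step that can be read from a single change: an at least 9.9-fold lower number from compound 3 to compound 4 (0.99 log units; beyond the scatter). What sits at this place on the ring therefore matters, as exchanging one heavy atom turns a compound without a number into one with a number. Compound 3 stands only at a limit, so this step gives a minimum size, not an exact one: the limit of > 20000 nM in this assay, at which 1 of the 4 values shown sits.

As far as these compounds go, whether an amine or a carboxylic acid at this place would give a lower or a higher number remains open. So does whether chloro would bring a similar step elsewhere on this ring.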